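The compounds below may be only part of what the source reports. "The series", "measured", "known", "first", "only" and "open" are said of these compounds alone.

Three compounds share one core and differ only in the aromatic group that sits on an amine nitrogen in a ring. Compound 1 `Nc1scc(CN2CCN(c3cccc(C(F)(F)F)c3)CC2)c1C(=O)c1ccc(Cl)cc1` carries 3-(trifluoromethyl)phenyl there, and in an assay on CHO cells for displacement of a labelled ligand from adenosine receptor A3 (Homo sapiens), read by scintillation counting, with a stated time of 120 min, tested at 10 uM (a lower number here means less inhibition, a higher number more inhibition at the concentration tested (going by the name of the read-out)), compound 1 gives 0%. Compound 2 `Nc1scc(CN2CCN(c3ccc(OC(F)(F)F)cc3)CC2)c1C(=O)c1ccc(Cl)cc1` carries 4-(trifluoromethoxy)phenyl, and in this assay compound 2 gives 1%. Compound 3 `Nc1scc(CN2CCN(c3cccc4ccccc34)CC2)c1C(=O)c1ccc(Cl)cc1` carries naphthalen-1-yl, and in this assay compound 3 gives 0%. On these numbers compound 3 stands level with compound 1, the two together the lowest of the three, with compound 2 the furthest from it; yet the steps of a number 1 percentage points higher from compound 1 to compound 2 (within the scatter), no change at the digits printed from compound 1 to compound 3 (within the scatter) and a number 1 percentage points lower from compound 2 to compound 3 (within the scatter) are all within the scatter, so none of the three can be set apart from the others.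

Compound 4 `Nc1scc(CN2CCN(c3c(F)cc(F)cc3F)CC2)c1C(=O)c1ccc(Cl)cc1` is the unmeasured member of the set. The change from compound 3 is 2,4,6-trifluorophenyl in place of naphthalen-1-yl on an amine nitrogen in a ring. All three measured steps bear on this change, since each also swaps one aromatic group for another on the same ring nitrogen, and each left this assay within the scatter. Hence no step beyond the scatter is expected, in either direction. Compound 4 is therefore expected to give about 1%, within -6% to 10%, which means an expected step of a number 1 percentage points higher from compound 3 to compound 4 (within the scatter).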

Compound 4, a percentage reported as inhibition, at one concentration (the size of the read-out at that concentration, not a potency): 0%
Compound 4: middle estimate off by 1 percentage points, on the high side; the measured number falls inside the stated range.
By their numbers in this assay, from the lowest: compounds 1, 3, 4 and 2 (each within the scatter of the next).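

In this assay, the swap that replaces naphthalen-1-yl, with its two six-membered aromatic rings, by 2,4,6-trifluorophenyl, with one such ring and three fluorine atoms, brings no change at the digits printed from compound 3 to compound 4 (within the scatter) and so leaves the read-out where it was. The same group set against the two other single-ring groups on this ring nitrogen brings a number 1 percentage points lower from compound 2 to compound 4 (within the scatter) and no change at the digits printed from compound 1 to compound 4 (within the scatter), which extends the flat picture to a ring carrying three fluorine atoms, so four different aromatic groups at this position now cannot be told apart at the one concentration tested. Nothing measured here offers an explanation for why these numbers stay together.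

From the compounds shown here alone, all four groups on this nitrogen are aromatic rings without hydrogen-bond donors or acceptors, so it remains open whether a phenyl ring bearing a carboxylic acid or an amine, or a longer alkyl chain in place of the ring, would move the read-out at all. Since every change shown sits at this one position, the compounds also leave open whether a change elsewhere on the shared core would do so.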